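The compounds below may be only part of what the source reports. "The series", "measured", "known", "first", "only" and "open" are said of these compounds alone.

The three measured compounds share one core and differ in the aryl group hung on an oxygen. Compound 1 `Cc1nn(C)c(Oc2ccc(Cl)cc2)c1/C=N\CCCCCOc1cc2oc(=O)cc(C)c2cc1Cl` carries a chlorophenyl group there; in a functional assay on HepG2 cells (Homo sapiens) for antiproliferative activity, read by MTT assay, with a stated time of 72 h (on this read-out lower numbers stand for stronger inhibition and higher numbers for weaker inhibition), compound 1 gives 15300 nM. Compound 2 `Cc1nn(C)c(Oc2ccc(I)cc2)c1/C=N\CCCCCOc1cc2oc(=O)cc(C)c2cc1Cl` has iodo in place of that chloro on an aromatic carbon. In this assay compound 2 reaches only the limit of the measurement, > 25000 nM. The step of an at least 1.6-fold higher number from compound 1 to compound 2 (0.21 log units; that floor lies within the scatter) is therefore known only as a floor, not as a number.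

Compound 3 `Cc1nn(C)c(Oc2ccccc2F)c1/C=N\CCCCCCOc1cc2oc(=O)cc(C)c2cc1Cl` carries a 2-fluorophenyl group and a chain one unit longer. In this assay compound 3 also stops at the limit, > 25000 nM. Compound 3 thus stands at the limit of this assay, a point shared by one other value shown, (the limit of > 25000 nM in this assay, at which 2 of the 3 values shown sit).

Compound 4 `Cc1nn(C)c(Oc2cccc(Cl)c2)c1/C=N\CCCCCCOc1cc2oc(=O)cc(C)c2cc1Cl` differs from compound 3 by 3-chlorophenyl in place of 2-fluorophenyl on an oxygen on an aromatic ring. Within the data shown here, no measured step covers this change: the only measured step swaps one halogen for another on the same aryl group and itself ends at a limit. There is no basis to expect a shift beyond the scatter, so compound 4 is expected near the limit as well. The estimate for compound 4 is 25000 nM, with a range from 8000 nM to 60000 nM, which means an expected step of a number no higher from compound 3 to compound 4 (the limit leaves the size open).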

Compound 4, half-maximal inhibitory concentration: 6220 nM
For compound 4 the middle estimate is 4.0-fold (0.60 log units) above the measured one; the whole stated range lies above it.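

Among these compounds, the aryl group on this oxygen matters in this assay, even though the only earlier step, a swap of one halogen for another, could not be told apart from the scatter: the new change gives an at least 4.0-fold lower number from compound 3 to compound 4 (0.60 log units; beyond the scatter). Compound 4 gives a measured 6220 nM. So a compound with this chain can come off the limit, and 3-chlorophenyl is the group on the oxygen that does so here. The true gap may be larger than the printed floor, since only one end of the step is a real number: the limit of > 25000 nM in this assay, at which 2 of the 4 values shown sit.

The change from 2-fluorophenyl to 3-chlorophenyl alters both the halogen and its place on the ring, so the compounds shown cannot say which of the two matters, and a 3-fluorophenyl or 2-chlorophenyl group on the same chain would be needed to separate them. On these data alone, it also stays open whether a non-halogen group such as 3-methoxyphenyl or 3-aminophenyl would do as well, and whether a longer chain would change the result, since compound 1 and compound 4 differ in more than one place and cannot be compared directly.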